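From furan-3-yl to 6-amino-5-methylpyridin-3-yl in compound 2

A few compounds are considered here, and "the series" means these few. Any claim that something is new, unique, unknown or untested is made for them only; others in the source may bear on it.

Three compounds have been measured in an in vitro assay on HEK385-7 cells for displacement of a labelled ligand from prostaglandin D2 receptor 2 (Homo sapiens); on this read-out lower numbers stand for stronger inhibition and higher numbers for weaker inhibition:
Compound 1, `O=C(O)Cc1sc(C(c2ccccc2)c2ccccc2)nc1-c1ccccc1`, gives 570 nM.
Compound 2, `O=C(O)Cc1sc(C(c2ccc(F)cc2)c2ccc(F)cc2)nc1-c1ccoc1`, gives 14 nM.
Compound 3, `O=C(O)Cc1sc(C(c2ccccc2)c2ccc(Cl)cc2)nc1-c1ccc(Cl)cc1`, gives 45 nM.

Compound 2 gives the lowest number of the three in this assay, and its gaps to compound 3 and to compound 1 both lie beyond the usual scatter, so it is the strongest binder shown. Compound 4, `Cc1cc(-c2nc(C(c3ccc(F)cc3)c3ccc(F)cc3)sc2CC(=O)O)cnc1N`, has not been measured yet. It differs from compound 2 in one place: 6-amino-5-methylpyridin-3-yl in place of furan-3-yl on an aromatic carbon. Among the measured compounds shown here, no step between measured compounds tells how this assay answers such a change, so the step is expected to be small, at most modestly towards a higher number, and may stay within the scatter. Compound 4 is estimated at 25 nM, between 6 nM and 100 nM, meaning an expected step of a 1.8-fold higher number from compound 2 to compound 4 (0.25 log units; within the scatter).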

Compound 4, half-maximal inhibitory concentration: 880 nM
Estimate against measurement, compound 4: 35-fold (1.55 log units) below; the whole stated range lies below it.
By their numbers in this assay, from the lowest: compound 2; then compound 3; then compounds 1 and 4 (each within the scatter of the next).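

Among the compounds shown here, the first comparison in this assay that changes one place alone shows that this position, next to the ring nitrogen, is sensitive to what it carries: 6-amino-5-methylpyridin-3-yl in place of furan-3-yl gives a 63-fold higher number from compound 2 to compound 4 (1.80 log units; beyond the scatter). The earlier compounds shown here could not show this, as each differed from the others in more than one place. Nothing measured here explains why the step is so large.

From the compounds shown here alone, it remains open whether the ring, the amine or the methyl accounts for the step. Plain pyridin-3-yl, 6-aminopyridin-3-yl and 5-methylpyridin-3-yl at this position would separate these three parts.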